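This account rests on a few compounds, and the source may have more. Where it says the series, first, only, none or still open, it means among the compounds named here.

Compound 1, `O=c1c2ccoc2ccn1[C@@H]1O[C@H](COP(=O)(O)OP(=O)(O)OP(=O)(O)O)[C@@H](O)[C@H]1O`, gives 68 nM in a functional assay for agonist activity at P2Y purinoceptor 2 (Homo sapiens), read by FLIPR; a lower number here means that less compound is needed, a higher number that more compound is needed for the effect. Compound 2, `Cc1cccc2ccn([C@@H]3O[C@H](COP(=O)(O)OP(=O)(O)OP(=O)(O)O)[C@@H](O)[C@H]3O)c(=O)c12`, gives 85 nM in this assay. Compound 3, `CSc1cc2ccn([C@@H]3O[C@H](COP(=O)(O)OP(=O)(O)OP(=O)(O)O)[C@@H](O)[C@H]3O)c(=O)c2cc1F`, gives 3 nM in this assay.

Of these three, compound 3 shows the lowest number: compound 1 and compound 2 both sit well above it, and in each case the gap lies beyond the usual scatter of repeated measurements. Compound 3 is therefore the point from which the next compound is judged.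

Compound 4, `COc1cc2ccn([C@@H]3O[C@H](COP(=O)(O)OP(=O)(O)OP(=O)(O)O)[C@@H](O)[C@H]3O)c(=O)c2cc1F`, is built from compound 3 by one change: methoxy in place of methylsulfanyl on an aromatic carbon. Among the measured compounds shown here, no measured pair in this set shows this exchange, so its effect is not known from these data and can only be estimated. A loss of some size is expected rather than a gain, but the rest of the structure is kept intact, so compound 4 is expected to stay closer to compound 3 than to compound 1 or compound 2. The estimated step of a 2.7-fold higher number from compound 3 to compound 4 (0.43 log units; beyond the scatter) is a modest rise in the number. For compound 4 the estimate in this assay is 8 nM, with a range from 2 nM to 30 nM.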

Compound 4, half-maximal effective concentration: 6 nM
Compound 4: the middle estimate sits 1.3-fold (0.12 log units) above what was measured, within the range that was stated.
By their numbers in this assay, from the lowest: compounds 3 and 4 (each within the scatter of the next); then compounds 1 and 2 (each within the scatter of the next).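

In this assay, among the compounds shown here, the exchange of methylsulfanyl for methoxy on this aromatic carbon, ortho to a fluoro group, comes to a 2.0-fold higher number from compound 3 to compound 4 (0.30 log units; within the scatter) and gives the first reading of a single change in this set. It shows that the low number of compound 3 does not depend on the sulfur atom of methylsulfanyl, since the oxygen of methoxy in the same place leaves the two compounds indistinguishable in this measurement. No other kind of measurement is available that bears on this result.

On these data alone, how an amine, a longer chain such as ethoxy, or a lone hydrogen on this carbon would read remains open. As far as these compounds go, compound 3 and compound 4 both carry the fluoro group, so its own contribution to their numbers also remains open.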